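Trimming a thiophene arm at the cytotoxicity limit

The source may report more compounds than this note shows. Statements on the series, on what has been measured and on what is new or still open speak of the compounds shown alone.

Compound 1, `Fc1cccc(F)c1Cc1cnc(Nc2ccc(-c3ccncc3)c(Cl)c2)o1`: 9300 nM.
Compound 2, `Clc1cccc(Cl)c1Cc1nnc(Nc2ccc(COCc3ccsc3)cc2)o1`: > 100000 nM.

Both measured compounds were tested in an ADME assay on MT2 cells (Homo sapiens) for cytotoxicity, read by MTT assay; on this read-out lower numbers stand for higher toxicity in this test and higher numbers for lower toxicity in this test. Compound 1 gives a numerical value of 9300 nM. For compound 2 the read-out is a limit of the assay rather than a number: compound 2 stands at the limit of > 100000 nM in this assay, at which 1 of the 2 values shown sits. Among the measured compounds shown here, no two measured compounds here differ in a single place, so no measured step is available to lean on.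

Compound 3, `COCc1ccc(Nc2nnc(Cc3c(Cl)cccc3Cl)o2)cc1`, is the unmeasured partner of compound 2. The change from compound 2 to compound 3 is hydrogen in place of thiophen-3-yl on a saturated chain carbon bound to an oxygen on a saturated carbon. The part that leaves is a small aromatic ring at the outer end of the chain; the core and the rest of the molecule are kept unchanged.

With compound 2 already at the limit, the step of a number no higher from compound 2 to compound 3 (the limit leaves the size open) is expected to be none beyond the scatter, and the read-out for compound 3 is expected to return again as a limit rather than a number. Compound 3 is estimated at 100000 nM, within a range from 40000 nM to 300000 nM.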

Compound 3, half-maximal cytotoxic concentration: 100000 nM
For compound 3 middle estimate and measured number coincide at the digits printed; the range from low to high includes it.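

Removing thiophen-3-yl from the saturated chain carbon bound to an oxygen on a saturated carbon leaves a methoxymethyl group, and in this assay compound 3 gives a number, 100000 nM. Compound 2 remains a limit of the assay and not a number: the limit of > 100000 nM in this assay, at which 1 of the 3 values shown sits. The change therefore reads as a number no higher from compound 2 to compound 3 (the limit leaves the size open), and although its size cannot be read, the pair shows that this position can lose the whole thiophen-3-yl ring while the compound still stands high on this read-out, where higher numbers stand for lower toxicity in this test.

The compounds shown leave open how this assay would read with an amine, a carboxylic acid or a phenyl ring on that same saturated chain carbon. They also leave open how far compound 2 lies from compound 3 , a distance that only a number for compound 2 in place of its limit could settle.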